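A few compounds are considered here, and "the series" means these few. Any claim that something is new, unique, unknown or untested is made for them only; others in the source may bear on it.

Measured so far in a functional assay on A549 cells (Homo sapiens) for inhibition, read by sulforhodamine B assay, with a stated time of 74 h; on this read-out higher numbers stand for weaker inhibition and lower numbers for stronger inhibition:
- compound 1 `CS(=O)(=O)N1C(=O)COC12C=CC(=O)C=C2`: > 10000 nM
- compound 2 `O=C1C=CC2(C=C1)OCC(=O)N2S(=O)(=O)c1ccc([N+](=O)[O-])cc1`: > 10000 nM
- compound 3 `O=C1C=CC2(C=C1)OCC(=O)N2S(=O)(=O)c1cccc(C(F)(F)F)c1`: 9610 nM

Compound 1 stands at the limit of > 10000 nM in this assay, at which 2 of the 3 values shown sit. Its entry is a limit of the assay and not a number, and no other value for it is available. The same holds for compound 2, whose > 10000 nM is also a limit. Among the measured compounds shown here, compound 3 gives 9610 nM, the only true number in the set.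

The next compound is compound 4 `O=C1C=CC2(C=C1)OCC(=O)N2S(=O)(=O)c1ccc(Br)s1`, which keeps the shared core and replaces one group: 5-bromothiophen-2-yl in place of methyl on a sulfonyl sulfur. Counted, the change is 5-bromothiophen-2-yl in place of methyl on a sulfonyl sulfur.

For the measured compounds named here, no measured pair of compounds differs in just one place, so there is no direct step to borrow for this assay. Compound 3 carries an aromatic ring on the sulfonyl sulfur and gives 9610 nM, which offers modest support for a move toward stronger inhibition. Compound 2 goes against this, with an aromatic ring there too and only a limit as its result.

The expected change is an at least 3.3-fold lower number from compound 1 to compound 4 (0.52 log units; beyond the scatter), a rough estimate given that its starting point is a limit. For compound 4 the estimated value is 3000 nM, with an expected range from 200 nM to 15000 nM.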

Compound 4, half-maximal inhibitory concentration: 50 nM
Compound 4: the middle estimate sits 60-fold (1.78 log units) above what was measured; the measured number lies below the stated range.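

In this assay, the group on the sulfonyl sulfur proves to matter a great deal, with an at least 200-fold lower number from compound 1 to compound 4 (2.30 log units; beyond the scatter) when 5-bromothiophen-2-yl replaces methyl. Compound 3 also carries an aromatic ring at this place and gives 9610 nM, while compound 4 gives 50 nM. An aromatic ring at this place is not enough in itself, as compound 2 also carries one and its entry is a limit. The true size of the step is not known, as the entry for compound 1 is a limit and not a number: the limit of > 10000 nM in this assay, at which 2 of the 4 values shown sit.

The compounds shown do not separate the bromine from the five-membered aromatic ring that carries it, so a plain thiophen-2-yl group, or a 5-chlorothiophen-2-yl group, would be the telling comparison. They also leave open whether the result holds beyond this assay, and what a ring bearing an amine or a carboxylic acid would give at this place.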